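Replacing a trifluoromethylphenyl group with a dichlorophenyl group

A few compounds are considered here, and "the series" means these few. Any claim that something is new, unique, unknown or untested is made for them only; others in the source may bear on it.

Compound 1 `CCOC(=O)/C(=C/c1ccccc1)CN1C(=O)[C@@H](OC)[C@H]1c1ccc(Cl)cc1`: "not toxic" (no number reported)
Compound 2 `COC(=O)/C(=C/c1ccccc1)CN1C(=O)[C@@H](OC)[C@H]1c1ccccc1C(F)(F)F`: "not toxic" (no number reported)
Compound 3 `COc1ccc(OC)c([C@@H]2[C@H](OC)C(=O)N2C/C(C#N)=C/c2ccccc2)c1`: > 100000 nM

These three compounds were tested in an ADME assay on cells (Epithelial cell, Homo sapiens) for antiproliferative activity, read by MTT assay, with a stated time of 48 h; a lower number here means a stronger inhibitor, a higher number a weaker inhibitor. In this test, compound 2 has no single number, and its entry reads "not toxic" (no number reported). Compound 1 has the same wording, "not toxic" (no number reported). Compound 3 gives > 100000 nM, which is a limit of the assay and not a number. Compound 2 therefore has no measured potency that can be set against another compound.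

The next compound is compound 4 `COC(=O)/C(=C/c1ccccc1)CN1C(=O)[C@@H](OC)[C@H]1c1ccc(Cl)cc1Cl`. The structural change is 2,4-dichlorophenyl in place of 2-(trifluoromethyl)phenyl on a saturated ring carbon. In words, 2,4-dichlorophenyl stands in place of 2-(trifluoromethyl)phenyl on a saturated ring carbon of a four-membered non-aromatic ring with 1 nitrogen.

Among the compounds with values here, no two measured compounds differ in just one place, so the data do not show how much a change of this kind can move the result. The expectation in this assay is therefore no step beyond the usual scatter, in either direction. It rests on compound 2 with "not toxic" (no number reported) and on compound 3 with > 100000 nM, a limit. Compound 4 may well be reported without a number too. For compound 4 the estimated value is 100000 nM, with an expected range from 30000 nM to 300000 nM.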

Compound 4, half-maximal inhibitory concentration: 70000 nM
For compound 4 the middle estimate is 1.4-fold (0.15 log units) above the measured one; low and high end bracket the measured number.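

In this assay compound 4 gives 70000 nM, but compound 2 has only the entry "not toxic" (no number reported), so no step can be read between them. The compounds shown leave open how far 2,4-dichlorophenyl in place of 2-(trifluoromethyl)phenyl moves the result on the shared core. The other reading here is a limit, not a number: the limit of > 100000 nM in this assay, at which 1 of the 4 values shown sits.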